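The compounds below may be only part of what the source reports. "The series", "measured", "known", "first", "only" and "open" are said of these compounds alone.

Among the measured compounds shown here, compound 1, `O=C1Nc2ccccc2/C1=C\c1c(Cl)n(Cc2ccccc2)c2ccccc12`, gives 47900 nM in a functional assay on cells (Cancer cell lines, Homo sapiens) for cytotoxicity, with a stated time of 48 h (a higher number here means a weaker inhibitor of growth, a lower number a stronger inhibitor of growth), the second highest of the three numbers measured so far. Compound 3, `O=C1/C(=C/c2c(Cl)[nH]c3ccccc23)c2ccccc2N1Cc1ccccc1`, gives 69200 nM in this assay, a gap to compound 1 that lies within the scatter. Compound 2, `COc1cc2c(/C=C3/C(=O)Nc4ccc(Cl)cc43)c(Cl)n(Cc3cc(OC)c(OC)c(OC)c3)c2cc1C`, gives 6030 nM, well beyond the scatter from compound 1 on the lower side. For the measured compounds named here, no pair of measured compounds differs in a single place, so no measured step is available to read the new change against. Compound 4, `O=C1Nc2ccccc2/C1=C\c1c(Cl)n(CCCc2ccccc2)c2ccccc12`, differs from compound 1 by phenethyl in place of phenyl on a saturated chain carbon bound to an aromatic nitrogen. Going by the values given here, with no comparable step in hand, the expected step of a 1.2-fold lower number from compound 1 to compound 4 (0.08 log units; within the scatter) is none beyond the scatter. Compound 4 is therefore estimated at 40000 nM in this assay, within 15000 nM to 100000 nM.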

Compound 4, concentration for total growth inhibition: 75900 nM
Beside the measured number, compound 4's estimate is 1.9-fold (0.28 log units) below it; the range from low to high includes it.
By their numbers in this assay, from the lowest: compound 2; then compounds 1, 3 and 4 (each within the scatter of the next).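

In this assay, the first step read at this position, phenethyl in place of phenyl on a saturated chain carbon bound to an aromatic nitrogen, gives a 1.6-fold higher number from compound 1 to compound 4 (0.20 log units; within the scatter) and so lies within the scatter. Going from benzyl to 3-phenylpropyl therefore produces no readable shift here, and the terminal phenyl ring remains present on both compounds. No measurement on hand bears on this result.

Open, as far as these compounds go, is whether an amine or a carboxylic acid in place of that terminal phenyl ring would give a step beyond the scatter. A longer chain also remains untested in the compounds shown.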